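A few compounds are considered here, and "the series" means these few. Any claim that something is new, unique, unknown or untested is made for them only; others in the source may bear on it.

Four close relatives of one core are compared here. Compound 1 `CC1(c2ccccc2)CC(=O)N(CC(=O)N2CCN(c3ccccc3F)CC2)C1=O` and compound 2 `CC1(c2ccccc2)CC(=O)N(CC(=O)N2CCN(c3ccc(Cl)cc3)CC2)C1=O` are measured in a functional assay on the whole organism (strain CD-1) with Mus musculus as the target, with a stated time of 2 h; on this read-out higher numbers stand for an effect only at larger amounts of compound and lower numbers for an effect already at smaller amounts: compound 1 gives 300 mg/kg, and compound 2 gives 300 mg/kg. For the measured compounds named here, the single step of no change at the digits printed from compound 1 to compound 2 (within the scatter) therefore shows that swapping one substituted phenyl ring on the amine nitrogen for another left the read-out where it was. Compound 3 `CC1(c2ccccc2)CC(=O)N(CC(=O)N2CCN(c3cccc(Cl)c3)CC2)C1=O` carries a 3-chlorophenyl on that same nitrogen. In this assay compound 3 gives "not active" (no number reported), a result reported without a number, so it sets no value on the scale. Compound 4 `CC1(c2ccccc2)CC(=O)N(CC(=O)N2CCN(c3ccccc3)CC2)C1=O` has not yet been measured in this assay. It differs from compound 3 by hydrogen in place of chloro on an aromatic carbon, which, read one bond further out, is 3-chlorophenyl to phenyl. Going by the values given here, no measured step walks this exact change; the only step known, from compound 1 to compound 2, was flat, and compound 3 stands outside the numbers. The plain phenyl is expected to land near compound 1 and compound 2, with a real chance of no number at all.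

Compound 4 is therefore estimated in this assay at 300 mg/kg, between 100 mg/kg and 1000 mg/kg.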

Compound 4, minimum effective dose: 300 mg/kg
Estimate against measurement, compound 4: no gap at the digits printed, within the range that was stated.
By their numbers in this assay, from the lowest: compounds 1, 2 and 4 (each within the scatter of the next).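

Removing the halogen altogether leaves the read-out in this assay unmoved: hydrogen in place of chloro gives no change at the digits printed from compound 2 to compound 4 (within the scatter) and hydrogen in place of fluoro gives no change at the digits printed from compound 1 to compound 4 (within the scatter) in the same way. A halogen on this phenyl ring is therefore not required for a number on this scale, as compound 4 gives 300 mg/kg with none. The step from compound 3 to compound 4 cannot be read, and nothing available explains why the 3-chlorophenyl compound alone has no number.

The compounds shown carry only hydrogen, fluoro or chloro on this ring, so the outcome with a methoxy group, an amine or a carboxylic acid there stays open. A 3-fluorophenyl ring would show whether the missing number of compound 3 goes with chloro alone or with any halogen in that place.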